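The compounds below may be only part of what the source reports. "The series", "measured", "known", "first", "only" and "open" are said of these compounds alone.

For the measured compounds named here, in a physicochemical assay for lipophilicity, read by HPLC (on this read-out lower numbers stand for lower lipophilicity and higher numbers for higher lipophilicity), compound 1 (`Cc1ccsc1C(=CCCN(C)C(CCO)C(=O)N1CCOCC1)c1sccc1C`) gives 4.75 as the lowest number so far. Compound 3 (`Cc1ccsc1C(=CCCN(C)C(CO)C(=O)NCc1ccc(F)cc1)c1sccc1C`) is nearest at 6.45 and stands beyond the scatter from compound 1. Compound 2 (`Cc1ccsc1C(=CCCN(C)C(CC(C)O)C(=O)NCc1ccccc1Cl)c1sccc1C`) has two entries (5.95; 5.67 (2 entries)) and both stand higher than compound 1. Compound 4 (`Cc1ccsc1C(=CCCN(C)C(CCO)C(=O)NCc1ccc(Cl)cc1)c1sccc1C`) departs from compound 1 in one place ((4-chlorobenzyl)amino in place of morpholin-4-yl on a carbonyl carbon), with (4-chlorobenzyl)amino in place of morpholin-4-yl on a carbonyl carbon. Going by the values given here, no step confined to one place has been measured. The expectation rests on compound 2 (5.95; 5.67 (2 entries)) and compound 3 (6.45), which also carry a benzyl group on the amide. In this assay the expected rise a number 1.45 log units higher from compound 1 to compound 4 (beyond the scatter) is well beyond the scatter. For compound 4 the estimated value is 6.2 with an expected range from 5.7 to 6.7 on present evidence.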

Compound 4, partition coefficient: 6.38
The estimate for compound 4 lay 0.18 log units below the measured number; the measured number falls inside the stated range.
By their numbers in this assay, from the lowest: compound 1; then compounds 4 and 3 (each within the scatter of the next).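

In this assay, the carbonyl carbon now has its first measured change confined to one place: (4-chlorobenzyl)amino in place of morpholin-4-yl gives a number 1.63 log units higher from compound 1 to compound 4 (beyond the scatter) with the shared core and the hydroxyl-bearing chain unchanged. This single change therefore moves the read-out by a large step, which clearly exceeds the spread between repeat entries: the several entries of compound 2 in this assay, 5.95; 5.67 (2 entries).

Still open, as far as these compounds go, is which part of the entering group carries the step. An unsubstituted benzylamino group or a dimethylamino group on the same carbonyl carbon would help separate the ring, the chlorine and the amide hydrogen.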